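The source may report more compounds than this note shows. Statements on the series, on what has been measured and on what is new or still open speak of the compounds shown alone.

Of the compounds shown here, three that share one core have so far been measured in a functional assay on isolated protein for inhibition of Glucose-dependent insulinotropic receptor (Rattus norvegicus), read by HTRF and cAMP accumulation; on this read-out lower numbers stand for smaller maximal responses and higher numbers for larger maximal responses. Compound 1 `Cc1nc(S(C)(=O)=O)ccc1Oc1ncnc(OC2CCN(C(=O)OC(C)(C)C#N)CC2)c1F` gives 97%, compound 2 `Cc1nc(S(C)(=O)=O)ccc1Oc1ncnc(OC2CCN(C(=O)OC(C)F)CC2)c1F` gives 68%, and compound 3 `Cc1nc(S(C)(=O)=O)ccc1Oc1ncnc(OC2CCN(C(=O)O[C@H](C)CF)CC2)c1F` gives 79%. On these numbers compound 3 stands second highest of the three: it sits a number 11 percentage points higher from compound 2 to compound 3 (beyond the scatter), while a number 18 percentage points lower from compound 1 to compound 3 (beyond the scatter). Both of these steps lie beyond the scatter, and both come from swapping the group on an oxygen next to a carbonyl group.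

Compound 4 `CCC1(OC(=O)N2CCC(Oc3ncnc(Oc4ccc(S(C)(=O)=O)nc4C)c3F)CC2)CC1` has not yet been measured. It differs from compound 3 in one place: 1-ethylcyclopropyl in place of 1-(fluoromethyl)ethyl on an oxygen next to a carbonyl group. The two measured steps that alter this same group, a number 18 percentage points lower from compound 1 to compound 3 (beyond the scatter) and a number 11 percentage points higher from compound 2 to compound 3 (beyond the scatter), were both modest in size. Going by the values given here, neither of them brings in a group made of carbon alone, nor a three-membered ring, so the change to compound 4 has no direct counterpart among the measured pairs. Among the compounds with values here, compound 1, which carries a 1-cyano-1-methylethyl on this oxygen, gives the highest number so far, so a modest rise from compound 3 is expected, with wide uncertainty. The expected step is a number 7 percentage points higher from compound 3 to compound 4 (within the scatter). For compound 4 the estimate in this assay is 86%, within a range from 68% to 102%.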

Compound 4, largest response reached (reported as efficacy), in percent of the reference or control that the assay uses: 83%
For compound 4 the middle estimate is 3 percentage points above the measured one; the measured number falls inside the stated range.
By their numbers in this assay, from the lowest: compound 2; then compounds 3 and 4 (each within the scatter of the next); then compound 1.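

In this assay, the 1-ethylcyclopropyl group, with its three-membered ring of carbon only, gives a number 4 percentage points higher from compound 3 to compound 4 (within the scatter), so a group with neither fluorine nor nitrile on this oxygen can read the same as the fluorine-bearing 1-(fluoromethyl)ethyl. Loss of the defined stereocentre in this change also brings no shift beyond the scatter. The other two comparisons place the new group between the earlier extremes, with a number 15 percentage points higher from compound 2 to compound 4 (beyond the scatter) and a number 14 percentage points lower from compound 1 to compound 4 (beyond the scatter), so this all-carbon group exceeds 1-fluoroethyl but falls short of 1-cyano-1-methylethyl, showing that this oxygen substituent can still move the maximal response in either direction.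

Nothing available here accounts for these differences. As far as these compounds go, it remains open how this read-out would respond to an amine, a longer alkyl chain or a cyclobutyl ring on this oxygen, and whether a nitrile placed on the 1-ethylcyclopropyl group would bring the number closer to that of compound 1.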